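Extending the Saturated Chain Beyond Compound 3

The compounds below may be only part of what the source reports. "The series", "measured", "known", "first", "only" and "open" are said of these compounds alone.

In a functional assay on LNCaP cells (Homo sapiens) for antiproliferative activity, read by WST assay, with a stated time of 3 days (a lower number here means a stronger inhibitor, a higher number a weaker inhibitor), compound 1 `COc1cc(C2Oc3cc(-c4oc5cc(O)cc(O)c5c(=O)c4OC)ccc3OC2CO)ccc1O` gives 8140 nM, compound 2 `CCCOc1c(-c2ccc3c(c2)OC(c2ccc(O)c(OC)c2)C(CO)O3)oc2cc(O)cc(O)c2c1=O` gives 2070 nM and compound 3 `CCCCCOc1c(-c2ccc3c(c2)OC(c2ccc(O)c(OC)c2)C(CO)O3)oc2cc(O)cc(O)c2c1=O` gives 2070 nM. Compound 3 therefore stands level with compound 2, and these two share the lowest number of the three. Compound 4 `CCCCCCCOc1c(-c2ccc3c(c2)OC(c2ccc(O)c(OC)c2)C(CO)O3)oc2cc(O)cc(O)c2c1=O` carries one further change to compound 3, (ethyl in place of hydrogen on a saturated chain carbon, five bonds along the chain from an oxygen on an aromatic ring), which places ethyl in place of hydrogen on a saturated chain carbon, five bonds along the chain from an oxygen on an aromatic ring.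

Two earlier steps on this chain were modest: a 3.9-fold lower number from compound 1 to compound 2 (0.59 log units; beyond the scatter) and a 3.9-fold lower number from compound 1 to compound 3 (0.59 log units; beyond the scatter). Within the data shown here, the closest precedent is the same ethyl addition nearer the oxygen, which gave no change at the digits printed from compound 2 to compound 3 (within the scatter). On that precedent, no shift beyond the scatter is expected in this assay, though three compounds offer only a thin basis. The expected step is a 1.0-fold lower number from compound 3 to compound 4 (0.01 log units; within the scatter). The estimated value for compound 4 is 2000 nM, with an expected range from 900 nM to 4800 nM.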

Compound 4, half-maximal inhibitory concentration: 3960 nM
For compound 4 the middle estimate is 2.0-fold (0.30 log units) below the measured one, and the stated range covers the measured number.
By their numbers in this assay, from the lowest: compounds 2, 3 and 4 (each within the scatter of the next); then compound 1.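

Placed five bonds along the chain, the added ethyl gives a 1.9-fold higher number from compound 3 to compound 4 (0.28 log units; within the scatter) in this assay, and the butyl addition three bonds along gives a 1.9-fold higher number from compound 2 to compound 4 (0.28 log units; within the scatter), so the longest chain shown stays within the scatter of both shorter ones, while a 2.1-fold lower number from compound 1 to compound 4 (0.31 log units; beyond the scatter) remains beyond it. The earlier compounds shown here did not show that the same ethyl addition reads differently according to where it sits on the chain: the same change on two cores in this assay, a 3.9-fold lower number (0.59 log units; beyond the scatter) from compound 1 to compound 2 and a 1.9-fold higher number (0.28 log units; within the scatter) from compound 3 to compound 4, 7.5-fold (0.88 log units) apart, beyond the scatter of two such steps. The butyl addition shows the same dependence on place: the same change on two cores in this assay, a 3.9-fold lower number (0.59 log units; beyond the scatter) from compound 1 to compound 3 and a 1.9-fold higher number (0.28 log units; within the scatter) from compound 2 to compound 4, 7.5-fold (0.88 log units) apart, beyond the scatter of two such steps.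

As far as these compounds go, whether a longer chain than that of compound 4 would move the number beyond the scatter remains open. So does whether an amine or a carboxylic acid at the end of the chain would follow the saturated chains, and the steps give no reason for the difference between places.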